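Biphenyl iminosugar ethers: moving the methoxy group

The source may report more compounds than this note shows. Statements on the series, on what has been measured and on what is new or still open speak of the compounds shown alone.

Compound 1 `Cc1cccc(-c2ccc(COCCCCCN3C[C@H](O)[C@@H](O)[C@H](O)[C@H]3CO)cc2)c1` and compound 2 `COc1ccc(-c2ccc(COCCCCCN3C[C@H](O)[C@@H](O)[C@H](O)[C@H]3CO)cc2)cc1` share the same core and differ only in the aryl terminus. In an assay on isolated protein for inhibition of Beta-glucosidase (Homo sapiens) (a higher number here means a weaker inhibitor, a lower number a stronger inhibitor), compound 1 gives 2 nM and compound 2 gives 10 nM, so compound 2 stands at the higher of the two numbers, the step of a 5.0-fold higher number from compound 1 to compound 2 (0.70 log units; beyond the scatter) being beyond the scatter. Compound 3 `COc1cccc(-c2ccc(COCCCCCN3C[C@H](O)[C@@H](O)[C@H](O)[C@H]3CO)cc2)c1` differs from compound 2 by 3-methoxyphenyl in place of 4-methoxyphenyl on an aromatic carbon. Among the measured compounds shown here, only that one step bears on this change, and it combines two alterations, so it guides the direction rather than the size. Compound 3 is expected to move back toward compound 1, an estimated 2.0-fold lower number from compound 2 to compound 3 (0.30 log units; within the scatter) in this assay, giving 5 nM with a range of 1.5 nM to 15 nM.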

Compound 3, half-maximal inhibitory concentration: 20 nM
For compound 3 the middle estimate is 4.0-fold (0.60 log units) below the measured one, and the stated range ends below it.
By their numbers in this assay, from the lowest: compound 1; then compounds 2 and 3 (each within the scatter of the next).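

Relocating the methoxy group, as 3-methoxyphenyl in place of 4-methoxyphenyl, gives a 2.0-fold higher number from compound 2 to compound 3 (0.30 log units; within the scatter) in this assay, so these two placements are not separated. With the position held, methoxy in place of methyl gives a 10-fold higher number from compound 1 to compound 3 (1.00 log units; beyond the scatter) and shows that the identity of the group matters here, which the earlier step, combining both alterations, could not isolate. Nothing at hand accounts for either step.

Open, from the compounds shown here alone, is whether the gap between methyl and methoxy persists with 4-methylphenyl as the terminus. Also open, going by these compounds, is how a hydroxyl or an amine would compare on this ring.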